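The source may report more compounds than this note shows. Statements on the series, on what has been measured and on what is new or still open speak of the compounds shown alone.

Within this set one core is kept and only the group on a saturated chain carbon bound to an amide-type nitrogen and a carbonyl carbon is exchanged. In a functional assay on the whole organism (Tail, strain ICR) with Mus musculus as the target, in the tail flick test, with a stated time of 120 min, at a dose of 25 umol/kg by the oral route (on this read-out lower numbers stand for a weaker effect and higher numbers for a stronger effect at the one dose given), compound 1 `CSCC[C@H](NC(=O)CN(c1nc(Cl)nc2[nH]cnc12)C1CC1)C(=O)OCc1ccccc1` gives 31.6%. Compound 2 `N=C(N)NCCC[C@H](NC(=O)CN(c1nc(Cl)nc2[nH]cnc12)C1CC1)C(=O)OCc1ccccc1` gives 10.2% in this assay, and compound 3 `CC[C@H](C)[C@H](NC(=O)CN(c1nc(Cl)nc2[nH]cnc12)C1CC1)C(=O)OCc1ccccc1` gives 22%. Compound 3 thus stands second highest of the three numbers: its nearest neighbour is compound 1, a number 9.6 percentage points lower from compound 1 to compound 3 (within the scatter), and the furthest is compound 2, a number 11.8 percentage points higher from compound 2 to compound 3 (beyond the scatter). The remaining step, a number 21.4 percentage points lower from compound 1 to compound 2 (beyond the scatter), is the largest seen in the set.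

Compound 4 `O=C(CN(c1nc(Cl)nc2[nH]cnc12)C1CC1)N[C@@H](CCC(=O)OCc1ccccc1)C(=O)OCc1ccccc1` carries the change (2-(benzyloxycarbonyl)ethyl in place of sec-butyl on a saturated chain carbon bound to an amide-type nitrogen and a carbonyl carbon). Among the measured compounds shown here, none of the measured steps brings in a group of this kind, so no step bears on it directly; the three steps show only that exchanging the group on this carbon moves the read-out by a modest amount, with compound 2 giving the lowest number of the three. A modestly lower value than that of compound 3 is expected for compound 4, a number 4 percentage points lower from compound 3 to compound 4 (within the scatter), and the uncertainty is wide. The estimate for compound 4 in this assay is 18%, with a range from 4% to 38%.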

Compound 4, a percentage reported as activity, at one dose (the size of the read-out at that dose, not a potency): 45.9%
Compound 4: middle estimate off by 27.9 percentage points, on the low side, and the stated range ends below it.
By their numbers in this assay, from the lowest: compound 2; then compounds 3 and 1 (each within the scatter of the next); then compound 4.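

In this assay the group on this saturated chain carbon can raise the read-out as well as lower it: 2-(benzyloxycarbonyl)ethyl gives the highest number of the series (a number 23.9 percentage points higher from compound 3 to compound 4 (beyond the scatter)), and it also clears the former top of the set (a number 14.3 percentage points higher from compound 1 to compound 4 (beyond the scatter)) and the lowest member (a number 35.7 percentage points higher from compound 2 to compound 4 (beyond the scatter)). Group size alone does not order the series, since the group of compound 2, larger than sec-butyl, gives the lowest number. Nothing at hand accounts for the rise.

On these data alone, it stays open which part of 2-(benzyloxycarbonyl)ethyl carries the gain, the benzyl ester, the six-membered aromatic ring or the chain length; a free carboxylic acid, a primary amide or a plain phenylethyl group on the same carbon would separate these. The comparison also rests on one oral dose and one time point, so a shift in the size of the effect cannot be told apart from a shift in its timing.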